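Methoxy added to the aromatic ring of compound 3

This account rests on a few compounds, and the source may have more. Where it says the series, first, only, none or still open, it means among the compounds named here.

In a functional assay on cells (Fibroblast) for antiproliferative activity (on this read-out higher numbers stand for weaker inhibition and lower numbers for stronger inhibition), compound 1 (`C=CCSS/C=C\C[S+]([O-])CCCO`) gives 22800 nM and compound 2 (`C=CCSS/C=C/C[S+]([O-])CCCN1C(=O)c2ccccc2C1=O`) gives 95900 nM on the same read-out. Compound 3 (`C=CCSS/C=C/C[S+]([O-])Cc1ccccc1`) gives 16600 nM in the same test. Compound 3 and compound 1 sit together at the low end of the three numbers, within the scatter of each other, while compound 2 lies higher, beyond the scatter.

Compound 4 (`C=CCSS/C=C/C[S+]([O-])Cc1ccc(OC)cc1`) differs from compound 3 in one place, as methoxy in place of hydrogen on an aromatic carbon shows: methoxy in place of hydrogen on an aromatic carbon, para to a large group. Among the compounds with values here, no two measured compounds differ in a single place, so the series gives no direct size for a step of this kind. The expectation therefore rests on compound 3 at 16600 nM as the starting point, and it is a weak one. A small shift towards a lower number is expected, with nothing beyond the scatter. The estimated step is a 1.1-fold lower number from compound 3 to compound 4 (0.04 log units; within the scatter) in this assay on this reading. For compound 4 the estimate is 15000 nM with a range from 7000 nM to 32000 nM as the expected bounds.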

Compound 4, half-maximal inhibitory concentration: 11200 nM
The estimate for compound 4 lay 1.3-fold (0.13 log units) above the measured number, within the range that was stated.
By their numbers in this assay, from the lowest: compounds 4, 3 and 1 (each within the scatter of the next, the first and the last beyond it); then compound 2.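

Within the data shown here, compound 3 and compound 4 are the first pair that differ in one place, so they give the first direct reading of a single step on the shared core. In this assay, methoxy in place of hydrogen on an aromatic carbon, para to a large group, gives a 1.5-fold lower number from compound 3 to compound 4 (0.17 log units; within the scatter), and the two compounds cannot be told apart on this read-out. Among these compounds, this position of the six-membered aromatic ring therefore accepts methoxy with no loss of antiproliferative activity beyond the scatter, which the earlier compounds could not show, as none of them forms such a pair with another. No measurement on hand gives a reason for this step.

Going by these compounds, a single substituent at a single place says little about the position as a whole, so it remains open whether an amine, a carboxylic acid or a chlorine atom at the same carbon would also stay within the scatter of compound 3. Also open, on these data alone, is whether methoxy on another carbon of the ring, or a longer chain in its place, would give a step beyond the scatter.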